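The source may hold more compounds than are shown below. What is called first, only, known or untested is meant among the compounds shown, and "the series" means these compounds.

Measured so far in a functional assay on HCT-116 cells (Homo sapiens) for antiproliferative activity, read by MTT assay, with a stated time of 24 h; a higher number here means a weaker inhibitor, a lower number a stronger inhibitor:
Compound 1 `C=CCOc1ccc2c(=O)c(-c3cc(OC)c(OC)cc3OC)coc2c1` gives 6600 nM.
Compound 2 `COc1ccc2c(=O)c(-c3cc(OC)c(OC)cc3OC)coc2c1` gives 9170 nM.

Within the data shown here, compound 2 carries the higher of the two numbers, but its only neighbour is compound 1, and the step of a 1.4-fold higher number from compound 1 to compound 2 (0.14 log units; within the scatter) lies within the scatter. Compound 3 `COc1cc(OC)c(-c2coc3cc(OCc4cccc(Cl)c4)ccc3c2=O)cc1OC` differs from compound 2 by 3-chlorophenyl in place of hydrogen on a saturated chain carbon bound to an oxygen on an aromatic ring. Among the measured compounds shown here, the one step measured at this place, a 1.4-fold higher number from compound 1 to compound 2 (0.14 log units; within the scatter), hardly moved the number, so no step beyond the scatter is expected here. Compound 3 is therefore estimated at 6000 nM, with a range from 2000 nM to 20000 nM. That expectation amounts to a 1.5-fold lower number from compound 2 to compound 3 (0.18 log units; within the scatter).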

Compound 3, half-maximal inhibitory concentration: 1330 nM
Compound 3: the middle estimate sits 4.5-fold (0.65 log units) above what was measured, outside the stated range (below it).
By their numbers in this assay, from the lowest: compound 3; then compounds 1 and 2 (each within the scatter of the next).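

This position can move the number after all: in this assay, replacing hydrogen with 3-chlorophenyl on a saturated chain carbon bound to an oxygen on an aromatic ring gives a 6.9-fold lower number from compound 2 to compound 3 (0.84 log units; beyond the scatter), and replacing vinyl with 3-chlorophenyl there gives a 5.0-fold lower number from compound 1 to compound 3 (0.70 log units; beyond the scatter). So the small difference between the earlier pair did not describe every change at this place. Nothing available explains why this change moves the number. The compounds shown leave open whether the chlorine or the ring itself accounts for these steps, and how a plain benzyl group or a chain ending in an amine would compare.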